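Compound 2 to compound 4: 4-iodophenyl to 4-methoxyphenyl

This account rests on a few compounds, and the source may have more. Where it says the series, first, only, none or still open, it means among the compounds named here.

In a functional assay on K562 cells (Homo sapiens) for cytotoxicity, read by MTT assay, with a stated time of 72 h (a higher number here means a weaker inhibitor, a lower number a stronger inhibitor), compound 1 (`Cc1ccc(S(=O)(=O)n2cc(COC3=C/C(=N\c4ccccc4)c4ccccc4C3=O)nn2)cc1`) gives 12200 nM, compound 2 (`Cc1ccc(S(=O)(=O)n2cc(COC3=C/C(=N\c4ccc(I)cc4)c4ccccc4C3=O)nn2)cc1`) gives 10800 nM and compound 3 (`Cc1ccc(/N=C2\C=C(OCc3cn(S(=O)(=O)c4ccc(C)cc4)nn3)C(=O)c3ccccc32)cc1`) gives 6220 nM. Compound 2 is thus not separated from either of the other two. Compound 4 (`COc1ccc(/N=C2\C=C(OCc3cn(S(=O)(=O)c4ccc(C)cc4)nn3)C(=O)c3ccccc32)cc1`) carries methoxy in place of iodo on an aromatic carbon, para to a large group: methoxy in place of iodo on an aromatic carbon. Three measured changes at this place bear on it: a 1.1-fold lower number from compound 1 to compound 2 (0.05 log units; within the scatter), a 2.0-fold lower number from compound 1 to compound 3 (0.29 log units; within the scatter) and a 1.7-fold lower number from compound 2 to compound 3 (0.24 log units; within the scatter), all within the scatter. No step beyond the scatter is therefore expected in this assay. The estimated step is a 1.4-fold lower number from compound 2 to compound 4 (0.13 log units; within the scatter). For compound 4 the expected value is 8000 nM, with an estimated range of 3500 nM to 17000 nM.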

Compound 4, half-maximal inhibitory concentration: > 20000 nM
Compound 4: only a limit was reported (the forecaster's own chance of this, stated with the estimate: 4%); at least 2.5-fold (0.39 log units) between middle value and limit.
By their numbers in this assay, from the lowest: compounds 3, 2 and 1 (each within the scatter of the next). At a limit, above all of these: compound 4.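

In this assay compound 4 gives > 20000 nM, a limit and not a number: the limit of > 20000 nM in this assay, at which 1 of the 4 values shown sits.

For the compounds shown here, at this place, para to a large group, an at least 3.2-fold higher number from compound 3 to compound 4 (0.50 log units; beyond the scatter) is the first step in the set beyond the scatter, so methoxy and methyl are not interchangeable here. The floors of an at least 1.8-fold higher number from compound 2 to compound 4 (0.26 log units; that floor lies within the scatter) and an at least 1.6-fold higher number from compound 1 to compound 4 (0.21 log units; that floor lies within the scatter) stay within the scatter, leaving methoxy unseparated from iodo and hydrogen.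

From the compounds shown here alone, the true size of these steps remains open. So does whether the oxygen link or the whole methoxy group drives the difference, which a hydroxyl, ethoxy or dimethylamino group at this place could address.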